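From Vinyl to But-1-en-1-yl on Compound 3

A few compounds are considered here, and "the series" means these few. Any claim that something is new, unique, unknown or untested is made for them only; others in the source may bear on it.

Three compounds of this series share one core. Compound 1 `COc1ccc(Nc2nc(Oc3cccc(NC(=O)/C=C/C(C)C)c3)c3sccc3n2)cc1` has no result in an ADME assay on L02 cells (Homo sapiens) for inhibition, read by MTT assay, with a stated time of 72 h (on this read-out higher numbers stand for weaker inhibition and lower numbers for stronger inhibition), where its entry reads "not determined" (no result reported). Compound 2 `C=CC(=O)Nc1cccc(Oc2nc(Nc3cccc(OC)c3)nc3ccsc23)c1` gives 30300 nM in this assay. Compound 3 `C=CC(=O)Nc1cccc(Oc2nc(Nc3cccc(C#N)c3)nc3ccsc23)c1` reaches only a limit of this assay, > 50000 nM, which is not a number. Among the compounds with values here, the one measured step, an at least 1.6-fold higher number from compound 2 to compound 3 (0.21 log units; that floor lies within the scatter), stays at a floor that lies within the scatter. Compound 3 thus stands at the limit of > 50000 nM in this assay, at which 1 of the 3 values shown sits, and the series holds one further entry without a number.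

Compound 4 `CC/C=C/C(=O)Nc1cccc(Oc2nc(Nc3cccc(C#N)c3)nc3ccsc23)c1` differs from compound 3 by but-1-en-1-yl in place of vinyl on a carbonyl carbon. No measured step touches the chain on the carbonyl carbon, so the exchange of vinyl for but-1-en-1-yl has no precedent among these compounds, and compound 3 itself gives only a limit. The step expected here, a number no higher from compound 3 to compound 4 (the limit leaves the size open), is none beyond the scatter. Compound 4 is expected to give about 50000 nM in this assay, within 25000 nM to 100000 nM, and most likely again to be reported only as a limit.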

Compound 4, half-maximal inhibitory concentration: > 50000 nM
Compound 4: only a limit was reported (the forecaster's own chance of this, stated with the estimate: 80%); the middle value sits exactly at the limit.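

In this assay, within the data shown here, compound 3 and compound 4 are each reported only as a limit, so no step between them can be read. The compounds shown leave open how far but-1-en-1-yl in place of vinyl on a carbonyl carbon moves the result in this assay at all.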